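Swapping the aryl group on the ring nitrogen

A few compounds are considered here, and "the series" means these few. Any claim that something is new, unique, unknown or untested is made for them only; others in the source may bear on it.

Compound 3 `COc1cccc(OC)c1N1C(=O)CSC1c1cccc(C(=O)NCCCCc2ccccc2)c1` gives 41% in a functional assay on U2OS cells (Homo sapiens) for inhibition, read by CCK-8 assay, with a stated time of 72 h, tested at 1 uM (on this read-out higher numbers stand for more inhibition at the one concentration tested (going by the name of the read-out) and lower numbers for less inhibition), the highest of the three numbers shown, though its steps to both other compounds lie within the scatter. Compound 1 `Cc1cccc(N2C(=O)CSC2c2cccc(C(=O)NCCCCc3ccccc3)c2)c1` gives 39% and compound 2 `COc1cc(F)ccc1N1C(=O)CSC1c1cccc(C(=O)NCCCCc2ccccc2)c1` gives 34%. Compound 4 `O=C(NCCCCc1ccccc1)c1cccc(C2SCC(=O)N2c2ccccc2F)c1` differs from compound 3 in one place: 2-fluorophenyl in place of 2,6-dimethoxyphenyl on an amide-type nitrogen in a ring. Earlier exchanges of the group on that ring nitrogen moved the number little: a number 2 percentage points higher from compound 1 to compound 3 (within the scatter) and a number 7 percentage points higher from compound 2 to compound 3 (within the scatter), both within the scatter. No step beyond the scatter is therefore expected from this further exchange. The expected step is a number 3 percentage points lower from compound 3 to compound 4 (within the scatter). Compound 4 is estimated at 38%, with a range from 26% to 50%.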

Compound 4, a percentage reported as inhibition, at one concentration (the size of the read-out at that concentration, not a potency): 38%
Compound 4: middle estimate and measured number agree at the digits printed; low and high end bracket the measured number.
By their numbers in this assay, from the lowest: compounds 2, 4, 1 and 3 (each within the scatter of the next).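

In this assay, a phenyl group carrying only fluorine, with no methoxy or methyl group, fits the same flat picture on this ring nitrogen: a number 3 percentage points lower from compound 3 to compound 4 (within the scatter), a number 4 percentage points higher from compound 2 to compound 4 (within the scatter) and a number 1 percentage points lower from compound 1 to compound 4 (within the scatter). Even replacing 2,6-dimethoxyphenyl, with its 2 hydrogen-bond acceptors, by 2-fluorophenyl, with none, gives no step beyond the scatter. No measurement here accounts for this insensitivity.

All four groups at this position are substituted phenyl rings. Going by these compounds, whether a pyridyl ring, a cyclohexyl ring or an aminoalkyl chain there would give a larger step remains open.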